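This account rests on a few compounds, and the source may have more. Where it says the series, first, only, none or still open, it means among the compounds named here.

The study covers four compounds on one shared core. Compound 1 `CCc1cccc(-c2nn3c(c2-c2ccnc(Nc4ccc(S(N)(=O)=O)cc4)c2)C(C)C(C)(C)C3)n1` is the only one of the measured set to return a number: in a functional assay on K562 cells (Homo sapiens) for cytotoxicity, with a stated time of 72 h (on this read-out higher numbers stand for weaker inhibition and lower numbers for stronger inhibition), compound 1 gives 24000 nM. Compound 2 `COCC1c2c(-c3ccncc3)c(-c3cccc(C)n3)nn2CC1(C)C` fares differently. In this assay compound 2 gives > 100000 nM, which is a limit of the assay and not a number. Compound 3 `Cc1cc(-c2c(-c3cccc(C)n3)nn3c2C(C)C(C)(C)C3)ccn1` behaves the same way. In this assay compound 3 gives > 100000 nM, again a limit of the assay rather than a measured number. Compound 3 therefore stands at the limit of > 100000 nM in this assay, at which 2 of the 3 values shown sit, with no ranking possible against compound 2 and only the numbered value of compound 1 standing apart from it.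

Compound 4 `Cc1cccc(-c2nn3c(c2-c2ccncc2)C(C)C(C)(C)C3)n1` has not yet been measured. It differs from compound 3 by hydrogen in place of methyl on an aromatic carbon. For the measured compounds named here, no pair among the measured compounds differs in a single place, so no measured step gives a yardstick for this change. Since compound 3 sits at the limit, compound 4 is expected to remain there as well, with an estimated value of 100000 nM and a range from 30000 nM to 300000 nM. The expected step is a number no higher from compound 3 to compound 4 (the limit leaves the size open), nothing beyond the usual scatter.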

Compound 4, half-maximal inhibitory concentration: > 100000 nM
Compound 4 was reported as a limit; the forecaster's own chance of this, stated with the estimate: 70%; the middle value sits exactly at the limit.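

For the compounds shown here, compound 4 ends at a limit of the assay, as compound 2 and compound 3 do, so no step from either of them to compound 4 can be read: the limit of > 100000 nM in this assay, at which 3 of the 4 values shown sit. The compounds shown leave open whether hydrogen in place of methyl on an aromatic carbon changes the result in this assay at all.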